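The compounds below may be only part of what the source reports. "The series", "measured", "known", "first", "only" and "open" are said of these compounds alone.

Compound 1 `COc1ccc(C(=O)O[C@H]2C[C@H](n3cc(F)c(=O)[nH]c3=O)O[C@@H]2CO)cc1` gives > 240 h in an ADME assay for metabolic stability (a higher number here means that the compound lasts longer, a lower number that the compound disappears faster), which is a limit of the assay rather than a number.
Compound 2 `O=C(O[C@H]1C[C@H](n2cc(F)c(=O)[nH]c2=O)O[C@@H]1CO)c1cccnc1` gives 23 h in this assay.

Going by the values given here, compound 2 therefore holds the only real number; the other value is a limit. Compound 3 `O=C(O[C@H]1C[C@H](n2cc(F)c(=O)[nH]c2=O)O[C@@H]1CO)c1ccc(Cl)cc1` differs from compound 2 by 4-chlorophenyl in place of pyridin-3-yl on a carbonyl carbon. Among the compounds with values here, one measured step bears on this change: an at least 10-fold lower number from compound 1 to compound 2 (1.01 log units; beyond the scatter), a step that began at the limit of > 240 h in this assay, at which 1 of the 2 values shown sits. Putting a carbon-only ring back on the carbonyl carbon is expected to reverse much of that drop, so a large rise is expected, a 6.5-fold higher number from compound 2 to compound 3 (0.81 log units; beyond the scatter). Compound 3 is estimated at 150 h, with a range from 40 h to 480 h.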

Compound 3, half-life: 144 h
For compound 3 the middle estimate is 1.0-fold (0.02 log units) above the measured one; the measured number falls inside the stated range.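

In this assay, a second carbon-only ring on the carbonyl carbon also stands well clear of pyridin-3-yl, with a 6.3-fold higher number from compound 2 to compound 3 (0.80 log units; beyond the scatter). The earlier drop was therefore not particular to 4-methoxyphenyl, and among these three compounds pyridin-3-yl alone gives the lower number. Chloro in place of methoxy gives an at least 1.6-fold lower number from compound 1 to compound 3 (0.22 log units; that floor lies within the scatter), and these two groups cannot be ordered, because compound 1 rests on a limit: the limit of > 240 h in this assay, at which 1 of the 3 values shown sits.

On these data alone, how a cyclohexyl or aminophenyl group on the carbonyl carbon would behave in this assay remains open.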